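Aminophenyl Gives Way to Dichlorophenyl on the Carbonyl

The source may hold more compounds than are shown below. What is called first, only, known or untested is meant among the compounds shown, and "the series" means these compounds.

Measured so far in a functional assay on NCI-H522 cells (Homo sapiens) for cytotoxicity, read by sulforhodamine B assay, with a stated time of 48 h, tested at 0.1 uM; a higher number here means a weaker effect of the compound at the concentration tested, a lower number a stronger effect:
compound 1 `COc1ccc(-c2cc(/C=C/C(=O)c3ccc(N)cc3)[nH]n2)cc1`: 85%
compound 2 `COc1cc(-c2cc(/C=C/C(=O)c3ccc(N)cc3)[nH]n2)cc(OC)c1OC`: 92%

Compound 2 holds the higher of the two numbers in this assay, but compound 1 sits within the scatter of it, so the two read as alike. Compound 3 `COc1cc(-c2cc(/C=C/C(=O)c3ccc(Cl)c(Cl)c3)[nH]n2)cc(OC)c1OC` differs from compound 2 by 3,4-dichlorophenyl in place of 4-aminophenyl on a carbonyl carbon. For the measured compounds named here, no pair of measured compounds shows this change, so nothing indicates a step beyond the scatter; the expected step of a number 4 percentage points lower from compound 2 to compound 3 (within the scatter) is small and of no settled direction. Compound 3 is therefore estimated at 88%, with a range from 72% to 102%.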

Compound 3, a percentage reported as activity, at one concentration (the size of the read-out at that concentration, not a potency): 89%
The estimate for compound 3 lay 1 percentage points below the measured number, within the range that was stated.
By their numbers in this assay, from the lowest: compounds 1, 3 and 2 (each within the scatter of the next).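

In this assay, for the compounds shown here, 3,4-dichlorophenyl in place of 4-aminophenyl on the carbonyl carbon gives a number 3 percentage points lower from compound 2 to compound 3 (within the scatter), the first reading of any change at this position. The entering group carries no hydrogen-bond donor or acceptor and brings in chlorine, yet this swap does not separate the two compounds at the concentration tested. No supporting data bear on this outcome. The compounds shown leave open whether a carboxylic acid or a morpholine on the carbonyl carbon would give a step beyond the scatter. They also leave open whether 3,4-dichlorophenyl would read the same on the core of compound 1.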